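Sulfone and sulfide analogues as enzyme inhibitors

The source may report more compounds than this note shows. Statements on the series, on what has been measured and on what is new or still open speak of the compounds shown alone.

The measured compounds are compound 1 `Nc1nc(O)c2c(S(=O)(=O)c3ccc4ccccc4c3)cccc2n1` with 4.85, compound 2 `Nc1nc(O)c2c(Sc3ccc4ccccc4c3)cccc2n1` with 6.15, and compound 3 `Nc1nc(N)c2c(Sc3ccc4ccccc4c3)cccc2n1` with 6.92, all in an assay for inhibition of Dihydrofolate reductase (Homo sapiens); a lower number here means a less potent compound, a higher number a more potent compound, by a factor of ten per unit of this negative logarithm.

Compound 4 `Nc1nc(N)c2c(S(=O)(=O)c3ccc4ccccc4c3)cccc2n1` has not yet been measured. It differs from compound 1 by amino in place of hydroxy on an aromatic carbon. The same change separates compound 2 from compound 3: amino in place of hydroxy on an aromatic carbon. That step gave a number 0.77 log units higher from compound 2 to compound 3 (beyond the scatter). The difference between the core of compound 1 and the core of compound 2 is not broken down here; compound 1 gives the lowest of the three numbers.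

From compound 1 to compound 4 a step of similar size is expected, a number 0.75 log units higher from compound 1 to compound 4 (beyond the scatter), because the same change produced a number 0.77 log units higher from compound 2 to compound 3 (beyond the scatter). Compound 4 is therefore estimated at 5.6 in this assay.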

Compound 4, logarithm of the reciprocal of the active concentration, log(1/C): 4.82
For compound 4 the middle estimate is 0.78 log units above the measured one, and the stated range ends above it.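

On the core of compound 1, amino in place of hydroxy on an aromatic carbon gives a number 0.03 log units lower from compound 1 to compound 4 (within the scatter), so the change does not carry over from one core to the other in this series. Set side by side, the two steps differ: the same change on two cores in this assay, a number 0.77 log units higher (beyond the scatter) from compound 2 to compound 3 and a number 0.03 log units lower (within the scatter) from compound 1 to compound 4, 0.80 log units apart, beyond the scatter of two such steps. This shows that the gain seen on the sulfide core is absent on the sulfone core, but two pairs of compounds do not show why, nor how the change would behave on any further core.

The compounds shown leave open how a sulfoxide or a methylene link between the two ring systems would respond to the same change. They also leave open whether a methyl or a methoxy group on that aromatic carbon would depend on the core in the same way.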